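Swapping an aromatic group for cyclohexyl

This account rests on a few compounds, and the source may have more. Where it says the series, first, only, none or still open, it means among the compounds named here.

Measured in a functional assay on HeLa cells (Homo sapiens) for inhibition, read by MTT assay, with a stated time of 48 h; on this read-out higher numbers stand for weaker inhibition and lower numbers for stronger inhibition:
compound 1 `COc1ccc(C(c2c[nH]c3ccc(Br)cc23)c2c[nH]c3ccc(Br)cc23)cc1` gives 5500 nM
compound 2 `COc1ccc(C(c2c[nH]c3ccc(Br)cc23)c2c[nH]c3ccc(Br)cc23)cc1OC` gives 6100 nM
compound 3 `CN(C)c1ccc(C(c2c[nH]c3ccc(Br)cc23)c2c[nH]c3ccc(Br)cc23)cc1` gives 12800 nM
compound 4 `Brc1ccc2[nH]cc(C(c3c[nH]c4ccc(Br)cc34)C3CCCCC3)c2c1` is not yet measured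

Compound 3 has the highest number of the three, which makes it the weakest inhibitor here. Compound 4 differs from it by cyclohexyl in place of 4-(dimethylamino)phenyl on a saturated chain carbon bound to two aromatic carbons, that is, cyclohexyl in place of 4-(dimethylamino)phenyl on a saturated chain carbon. The closest evidence is a 2.3-fold higher number from compound 1 to compound 3 (0.37 log units; beyond the scatter) and a 2.1-fold higher number from compound 2 to compound 3 (0.32 log units; beyond the scatter), both modest, while a 1.1-fold higher number from compound 1 to compound 2 (0.04 log units; within the scatter) stayed within the scatter. All three steps keep an aromatic group, so none tests a non-aromatic ring and any forecast is loose. A modest move to a lower number in this assay is expected, an estimated 1.6-fold lower number from compound 3 to compound 4 (0.20 log units; within the scatter). Compound 4 is estimated at 8000 nM. Its expected range runs from 3000 nM to 20000 nM.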

Compound 4, half-maximal inhibitory concentration: 3200 nM
The estimate for compound 4 lay 2.5-fold (0.40 log units) above the measured number; the range from low to high includes it.
By their numbers in this assay, from the lowest: compounds 4, 1 and 2 (each within the scatter of the next); then compound 3.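

In this assay, putting cyclohexyl in place of 4-(dimethylamino)phenyl gives a 4.0-fold lower number from compound 3 to compound 4 (0.60 log units; beyond the scatter), so this saturated chain carbon can carry a non-aromatic ring without any loss. Set against the two methoxy-bearing aromatic groups, cyclohexyl gives a 1.9-fold lower number from compound 2 to compound 4 (0.28 log units; within the scatter) and a 1.7-fold lower number from compound 1 to compound 4 (0.24 log units; within the scatter), which means that among these four compounds an aromatic ring here is not needed to reach this level of inhibition. Nothing measured here explains these steps. Still open, as far as these compounds go, is whether a smaller cyclopentyl ring, an open hexyl chain or a cyclohexyl carrying an amine would hold this level.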